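The source may report more compounds than this note shows. Statements on the series, on what has been measured and on what is new or still open speak of the compounds shown alone.

Measured in a functional assay on HL-60 cells (Homo sapiens) for inhibition, read by CCK-8 assay, with a stated time of 48 h; on this read-out higher numbers stand for weaker inhibition and lower numbers for stronger inhibition:
Compound 1 `O=C(NCCNS(=O)(=O)c1ccc(-c2ccccc2OCc2cccc(O)c2)s1)Nc1cc(Cl)cc(Cl)c1`: 2800 nM
Compound 2 `O=C(NCCNS(=O)(=O)c1ccc(-c2ccccc2OCc2ccccc2)s1)Nc1cc(Cl)cc(Cl)c1`: 11700 nM

Compound 2 has the higher of the two numbers, meaning the weaker inhibition. Compound 3 `O=C(NCCNS(=O)(=O)c1ccc(-c2ccccc2O[C@H]2CC[C@H](O)CC2)s1)Nc1cc(Cl)cc(Cl)c1` carries 4-hydroxycyclohexyl in place of benzyl on an oxygen on an aromatic ring. Among the compounds with values here, the only measured step that bears on this is a 4.2-fold higher number from compound 1 to compound 2 (0.62 log units; beyond the scatter), with hydrogen in place of hydroxy on an aromatic carbon. Within the data shown here, no measured compound shows benzyl itself replaced. A modest move toward a lower number is therefore expected, an estimated 2.3-fold lower number from compound 2 to compound 3 (0.37 log units; beyond the scatter). Compound 3 is estimated at 5000 nM, with an expected range of 1500 nM to 17000 nM.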

Compound 3, half-maximal inhibitory concentration: > 20000 nM
Compound 3: a limit, no number; the forecaster's own chance of this, stated with the estimate: 5%; middle value at least 4.0-fold (0.60 log units) away from the limit.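

In this assay compound 3 gives > 20000 nM, which is a limit of the assay and not a number. Putting 4-hydroxycyclohexyl in place of benzyl on this oxygen gives an at least 1.7-fold higher number from compound 2 to compound 3 (0.23 log units; that floor lies within the scatter), so this floor alone does not establish a real loss against the benzyl ether. Against 3-hydroxybenzyl the same group gives an at least 7.1-fold higher number from compound 1 to compound 3 (0.85 log units; beyond the scatter), which shows that a hydroxy on the group does not by itself preserve the lower number once the aromatic ring is replaced by a non-aromatic one.

From the compounds shown here alone, it remains open how 3-aminobenzyl or 3-carboxybenzyl would read at this oxygen. Whether 4-aminocyclohexyl would behave like 4-hydroxycyclohexyl is equally unresolved.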